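Swapping the sulfonyl aryl group: from dimethyl to amino

The source may report more compounds than this note shows. Statements on the series, on what has been measured and on what is new or still open speak of the compounds shown alone.

Measured compounds:
compound 1 `COc1cc(C(=O)NS(=O)(=O)c2ccccc2OC)ccc1Cn1ccc2ccc(NC(=O)CC3CCCC3)cc21` gives 9.7
compound 2 `COc1cc(C(=O)NS(=O)(=O)c2ccccc2C)ccc1Cn1ccc2ccc(NC(=O)CC3CCCC3)cc21` gives 9.9
compound 3 `COc1cc(C(=O)NS(=O)(=O)c2cc(C)ccc2C)ccc1Cn1ccc2ccc(NC(=O)CC3CCCC3)cc21` gives 8.4

All three share one core and differ only in the aryl group on the sulfonyl sulfur. In a functional assay (trachea) for antagonist activity, with Cavia porcellus as the target (a lower number here means a less potent compound, a higher number a more potent compound, by a factor of ten per unit of this negative logarithm), compound 3 stands lowest of the three; its nearest neighbour is compound 1, and compound 2 lies furthest away. The step of a number 1.50 log units lower from compound 2 to compound 3 (beyond the scatter) and the step of a number 1.30 log units lower from compound 1 to compound 3 (beyond the scatter) both show that the 2,5-dimethylphenyl group costs potency.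

The new compound 4 `COc1cc(C(=O)NS(=O)(=O)c2ccccc2N)ccc1Cn1ccc2ccc(NC(=O)CC3CCCC3)cc21` is still to be measured. Compared with compound 3, the change is 2-aminophenyl in place of 2,5-dimethylphenyl on a sulfonyl sulfur. This removes the second methyl, whose addition in the step from compound 2 to compound 3 cost so much, and puts a single amino group where compounds 1 and 2 carry a single methoxy or methyl. Both of those single-substituent compounds sit high. Among the measured compounds shown here, no measured pair tells what an amino group itself does in this place, so some uncertainty remains, but the return to a singly substituted ring argues for a rise.

Compound 4 is therefore expected to climb by about a number 1.00 log units higher from compound 3 to compound 4 (beyond the scatter), giving an estimated 9.4 with a likely range from 8.6 to 10.1.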

Compound 4, negative logarithm of the antagonist equilibrium constant: 9.9
Compound 4: the middle estimate sits 0.50 log units below what was measured, within the range that was stated.
By their numbers in this assay, from the lowest: compound 3; then compounds 1, 2 and 4 (each within the scatter of the next).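

In this assay, among the compounds shown here, 2-aminophenyl in place of 2,5-dimethylphenyl on the sulfonyl sulfur gives a number 1.50 log units higher from compound 3 to compound 4 (beyond the scatter) and so recovers all the potency lost in compound 3, which shows that this position can hold a nitrogen-bearing group and not only the methyl and methoxy groups of the earlier compounds. Amino in place of methyl gives no change at the digits printed from compound 2 to compound 4 (within the scatter) and amino in place of methoxy gives a number 0.20 log units higher from compound 1 to compound 4 (within the scatter) in this comparison, so this assay does not separate these three single groups, even though 2-aminophenyl carries a hydrogen-bond donor. No measurement of any property of these groups is available to explain these steps.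

Going by these compounds, what plain phenyl would give, with no added group on the ring, stays open, so it is unclear whether a single group contributes anything at all. For the compounds shown here, equally open is whether a carboxylic acid or a dimethylamino group in place of the amino group would hold the potency, and whether a second group other than methyl would cost as much as the one in compound 3.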